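Adding Fluorine to the Aryl Ring of Compound 2

The source may report more compounds than this note shows. Statements on the series, on what has been measured and on what is new or still open speak of the compounds shown alone.

Compound 2 `Cn1ncc2c(NC(=O)NCc3cc(C(C)(C)C)nn3-c3ccc(Cl)cc3)cccc21` is measured in an assay on CHO-K1 cells for antagonist activity at transient receptor potential cation channel subfamily V member 1 (Homo sapiens), read by FLIPR and calcium flux, with a stated time of 6 min (on this read-out lower numbers stand for stronger inhibition and higher numbers for weaker inhibition), at 9.5 nM, the higher of the two numbers seen so far. Compound 1 `CC(C)(C)c1cc(CNC(=O)Nc2cccc3[nH]ncc23)n(-c2ccc(F)c(Cl)c2)n1` gives 0.5 nM in this assay, and the gap between compound 2 and compound 1 lies beyond the scatter. Compound 3 `Cn1ncc2c(NC(=O)NCc3cc(C(C)(C)C)nn3-c3ccc(F)c(Cl)c3)cccc21` has not been measured; it carries 3-chloro-4-fluorophenyl in place of 4-chlorophenyl on an aromatic nitrogen. Among the measured compounds shown here, no measured pair isolates this change, and compound 1 differs from compound 2 in more than this ring, so its value is only a hint. The expected step is a 2.4-fold lower number from compound 2 to compound 3 (0.38 log units; beyond the scatter), toward a lower number. Compound 3 is expected to give 4 nM in this assay, between 1.2 nM and 12 nM.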

Compound 3, inhibition constant: 0.6 nM
For compound 3 the middle estimate is 6.7-fold (0.82 log units) above the measured one; measured number outside the range, below it.
By their numbers in this assay, from the lowest: compounds 1 and 3 (each within the scatter of the next); then compound 2.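

The step of a 16-fold lower number from compound 2 to compound 3 (1.20 log units; beyond the scatter) comes from replacing 4-chlorophenyl with 3-chloro-4-fluorophenyl, so this single ring change is large on its own, something the earlier pair could not show. With that ring in place, the step of a 1.2-fold higher number from compound 1 to compound 3 (0.08 log units; within the scatter) for methyl in place of hydrogen on an aromatic nitrogen stays within the scatter. No measurement here explains the size of the ring effect. Still open, as far as these compounds go, is whether the fluorine or the chlorine's new place carries the step, which 4-fluorophenyl or 3-chlorophenyl could separate.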